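The source may report more compounds than this note shows. Statements on the series, on what has been measured and on what is new or still open speak of the compounds shown alone.

Three compounds have so far been measured in a functional assay on NCI-H460 cells (Homo sapiens) for inhibition, with a stated time of 72 h; a higher number here means a weaker inhibitor, a lower number a stronger inhibitor:

compound 1, `COc1ccc(S(=O)(=O)N2CCc3cccc(-c4ccc(F)cc4)c32)cc1`, gives 95.5 nM
compound 2, `COc1ccc(S(=O)(=O)N2CCc3cccc(-c4ccc(C#N)cc4)c32)cc1`, gives 29.5 nM
compound 3, `COc1ccc(S(=O)(=O)n2ccc3cccc(-c4ccc(F)cc4)c32)cc1`, gives 212 nM

Compound 2 stands lowest of these three numbers, and both of its gaps to the others lie beyond the scatter, so it is the strongest inhibitor of the set. Among the measured compounds shown here, the only single-point step measured is a 3.2-fold lower number from compound 1 to compound 2 (0.51 log units; beyond the scatter), a modest gain from adding the cyano group. Compound 3 shares the fluoro group of compound 1 and gives the highest number of the three.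

Compound 4, `COc1ccc(S(=O)(=O)N2CCc3cccc(-c4cccs4)c32)cc1`, has not yet been measured. Its change from compound 2 is thiophen-2-yl in place of 4-cyanophenyl on an aromatic carbon. The step from compound 1 to compound 2 bears on this only in part: it shows that the cyano group, now removed, was worth a modest lowering of the number. For the measured compounds named here, no measured compound carries thiophen-2-yl, so that part of the change is uncharted. A modest rise is therefore expected, roughly undoing that gain, which means an estimated 4.1-fold higher number from compound 2 to compound 4 (0.61 log units; beyond the scatter). Compound 4 is expected to give about 120 nM, between 35 nM and 450 nM.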

Compound 4, half-maximal inhibitory concentration: 229 nM
Estimate against measurement, compound 4: 1.9-fold (0.28 log units) below, and the stated range covers the measured number.
By their numbers in this assay, from the lowest: compound 2; then compound 1; then compounds 3 and 4 (each within the scatter of the next).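

Thiophen-2-yl on this aromatic carbon is the first group tested here that is not a substituted phenyl ring, and in this assay the swap for 4-cyanophenyl costs potency (a step of a 7.8-fold higher number from compound 2 to compound 4 (0.89 log units; beyond the scatter)). The loss is not simply that of the nitrile, since thiophen-2-yl also falls short of 4-fluorophenyl (a step of a 2.4-fold higher number from compound 1 to compound 4 (0.38 log units; beyond the scatter)), so replacing either substituted phenyl ring with this smaller five-membered ring weakens inhibition. No available evidence explains why this change has that effect.

As far as these compounds go, it remains open whether a nitrile placed on the thiophene ring would recover the potency seen with compound 2. Also unsettled is how a pyridine ring, a furan ring or a saturated amine such as morpholine would fare at this position.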